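Inverting the ring stereocentre of compound 1

A few compounds are considered here, and "the series" means these few. Any claim that something is new, unique, unknown or untested is made for them only; others in the source may bear on it.

Measured compounds:
- Compound 1 `COc1ccc(C#Cc2ccc(C(=O)N3CC[C@@H](O)C3)cc2)cc1`: 10200 nM
- Compound 2 `CSc1ccc(C#Cc2ccc(C(=O)N3CCC[C@@H](CO)C3)cc2)cc1`: > 10000 nM, a limit of the assay
- Compound 3 `COc1ccc(-c2nnc(-c3ccc(C(=O)N4CCC[C@@H](CO)C4)cc3)o2)cc1`: > 10000 nM, a limit of the assay

Among the measured compounds shown here, in a functional assay on TREX cells for negative allosteric modulation of metabotropic glutamate receptor 3 (Rattus norvegicus), read by calcium flux, with a stated time of 2.5 min (on this read-out higher numbers stand for weaker inhibition and lower numbers for stronger inhibition), compound 1 gives 10200 nM, the only actual number. Compound 2 reaches only > 10000 nM, which is a limit. Compound 3 likewise reaches only > 10000 nM, again a limit. Compound 1 therefore stands just at the edge of what the assay resolves, and the limit of > 10000 nM in this assay, at which 2 of the 3 values shown sit, frames the whole set as weak inhibition.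

Compound 4 `COc1ccc(C#Cc2ccc(C(=O)N3CC[C@H](O)C3)cc2)cc1` is the next compound to be measured. The change from compound 1 is the two compounds have the same atoms and bonds and differ only in configuration as drawn: 1 of 1 stereo elements differ; a stereocentre at a saturated ring carbon is drawn R in compound 1 and S in compound 4: no atom leaves and none enters, the two compounds have the same atoms and bonds and differ only in configuration as drawn. No measured pair in the series isolates this kind of change, so nothing shown gives the size or direction of the step in this assay. Compound 4 is expected to sit close to compound 1, with a step of a 1.1-fold higher number from compound 1 to compound 4 (0.03 log units; within the scatter) that is not expected to exceed the scatter. The estimate for compound 4 is 11000 nM, within 3500 nM to 30000 nM, and a limit rather than a number is a real possibility.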

Compound 4, half-maximal inhibitory concentration: 27500 nM
Compound 4: middle estimate off by 2.5-fold (0.40 log units), on the low side; measured number inside the range.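

In this assay the series now holds its first pair that isolates a single change, and inverting the stereocentre at the saturated ring carbon from R to S gives a 2.7-fold higher number from compound 1 to compound 4 (0.43 log units; beyond the scatter). This stereocentre is therefore not indifferent: the R form drawn in compound 1 gives the stronger inhibition of the pair, although the step is modest and both compounds remain weak. The step can be assigned to configuration alone: the fact that compounds 1 and 4 differ only in the configuration as drawn.

Still open, as far as these compounds go, is whether this preference for R survives when the hydroxyl group of compound 1 is replaced by an amine or a carboxylic acid, or whether it would hold in a compound with stronger inhibition. The whole comparison stays close to the ceiling of the read-out: the limit of > 10000 nM in this assay, at which 2 of the 4 values shown sit.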